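The source may report more compounds than this note shows. Statements on the series, on what has been measured and on what is new or still open speak of the compounds shown alone.

In an ADME assay on MT4 cells (Homo sapiens) for cytotoxicity, read by MTT assay (a higher number here means that more compound is tolerated, a lower number that less compound is tolerated), compound 2 (`Cc1ccc(NC(=O)CSc2nncnc2-c2cccc3ccccc23)c([N+](=O)[O-])c1`) gives 147000 nM as the higher of two numbers, with compound 1 (`Cc1ccc(NC(=O)CSc2nncnc2-c2ccccc2Cl)c(Br)c1`) at 45000 nM and the gap beyond the scatter. Compound 3 (`Cc1ccc(NC(=O)CSc2nncnc2-c2ccccc2Cl)c([N+](=O)[O-])c1`), still unmeasured, carries 2-chlorophenyl in place of naphthalen-1-yl on an aromatic carbon. For the measured compounds named here, no measured step isolates this change, so the expectation is tentative: a modest fall in this assay is expected, given that compound 1, which also carries 2-chlorophenyl, stands at 45000 nM with the shared core. The expected step is a 1.8-fold lower number from compound 2 to compound 3 (0.26 log units; within the scatter) on this reading. Compound 3 is estimated at 80000 nM (range 30000 nM to 180000 nM).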

Compound 3, half-maximal cytotoxic concentration: 158000 nM
The estimate for compound 3 lay 2.0-fold (0.30 log units) below the measured number; the range from low to high includes it.
By their numbers in this assay, from the lowest: compound 1; then compounds 2 and 3 (each within the scatter of the next).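

In this assay, 2-chlorophenyl in place of naphthalen-1-yl gives a 1.1-fold higher number from compound 2 to compound 3 (0.03 log units; within the scatter) with the nitro group held, so this position on the ring with 3 nitrogen takes either group without a change beyond the scatter. For the compounds shown here, with 2-chlorophenyl held, nitro in place of bromo gives a 3.5-fold higher number from compound 1 to compound 3 (0.55 log units; beyond the scatter) as the only step here beyond the scatter. Nothing measured explains either step.

Open, going by these compounds, is whether an amine or a carboxylic acid in place of the nitro group keeps the higher number. Also open, on these data alone, is whether unsubstituted phenyl in place of 2-chlorophenyl stays within the scatter.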